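The source may hold more compounds than are shown below. What is called first, only, known or untested is meant among the compounds shown, and "the series" means these compounds.

In a functional assay on HepG2 cells (Homo sapiens) for antiproliferative activity, read by MTT assay, with a stated time of 48 h (on this read-out lower numbers stand for stronger inhibition and higher numbers for weaker inhibition), compound 1 (`Cc1ccc(-c2nc(NO)c3cc(Cl)ccc3n2)cc1`) gives 23.1 ug/mL and compound 2 (`CSc1nc(-c2ccc(C)cc2)nc2ccc(Cl)cc12`) gives 13.3 ug/mL on the same read-out. These two numbers lie within the usual scatter of each other, so compound 2 stands level with compound 1 and neither can be ranked ahead.

Compound 3 (`C=CCSc1nc(-c2ccc(C)cc2)nc2ccc(Cl)cc12`) carries vinyl in place of hydrogen on a saturated chain carbon bound to a sulfur so that methylsulfanyl becomes allylsulfanyl. For the measured compounds named here, the only measured step at hand is a 1.7-fold lower number from compound 1 to compound 2 (0.24 log units; within the scatter) and it stayed within the scatter. That step swaps hydroxyamino for methylsulfanyl on an aromatic carbon, however, so it bears on the new change only indirectly. Going by the values given here, no measurement yet shows what happens when methylsulfanyl gives way to allylsulfanyl, and the data point in no direction. The safest expectation in this assay is therefore no step beyond the scatter, with compound 2 at 13.3 ug/mL as the anchor. The expected change is a 1.0-fold lower number from compound 2 to compound 3 (0.01 log units; within the scatter) and no more than that can be claimed. Compound 3 is estimated at 13 ug/mL with an expected range from 6 ug/mL to 27 ug/mL in this measurement.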

Compound 3, half-maximal inhibitory concentration: 23.9 ug/mL
Compound 3: middle estimate off by 1.8-fold (0.26 log units), on the low side; the measured number falls inside the stated range.
By their numbers in this assay, from the lowest: compounds 2, 1 and 3 (each within the scatter of the next).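

For the compounds shown here, putting vinyl in place of hydrogen on a saturated chain carbon bound to a sulfur turns methylsulfanyl into allylsulfanyl, and this gives the first direct reading of that swap in this assay: a 1.8-fold higher number from compound 2 to compound 3 (0.25 log units; within the scatter) stays within the usual scatter, so compound 2 and compound 3 stand level. The comparison with the hydroxyamino group on the aromatic carbon reads the same way, since a 1.0-fold higher number from compound 1 to compound 3 (0.01 log units; within the scatter) is also within the scatter, so hydroxyamino, methylsulfanyl and allylsulfanyl cannot be ranked at this position in these three compounds. Nothing at hand offers an explanation for these readings.

From the compounds shown here alone, it remains open whether a larger sulfur group, such as butylsulfanyl or benzylsulfanyl, would move the number beyond the scatter in either direction. Going by these compounds, it is equally open whether a group without sulfur on the same aromatic carbon, such as methoxy or a simple amine, would separate itself from these three compounds.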